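A few compounds are considered here, and "the series" means these few. Any claim that something is new, unique, unknown or untested is made for them only; others in the source may bear on it.

From the compounds shown here alone, the set holds three measured compounds and one still open. Compound 1 `COc1nc(C(C)(C)C)ccc1[C@@H](c1ccccc1)[C@@](O)(CCN(C)C)c1cccc2ccccc12` gives 27.6 ug/mL in a toxicity assay on Vero cells (Chlorocebus sabaeus) for cytotoxicity; a lower number here means that less compound is tolerated, a higher number that more compound is tolerated. Compound 2 `COc1nc(-c2ccc(Br)cc2)ccc1[C@@H](c1ccccc1)[C@@](O)(CCN(C)C)c1cccc2ccccc12` in this assay reaches only a limit of the assay, > 50 ug/mL. Compound 3 `COc1ncc(-c2ccccc2)cc1[C@@H](c1ccccc1)[C@@](O)(CCN(C)C)c1cc(F)ccc1F` likewise stops at a limit in this assay, > 50 ug/mL. Among the compounds with values here, the one step between measured compounds that differ in a single place is an at least 1.8-fold higher number from compound 1 to compound 2 (0.25 log units; that floor lies within the scatter), with 4-bromophenyl in place of tert-butyl on an aromatic carbon. Compound 2 thus stands at the upper edge of what this assay reports, a position summed up in the limit of > 50 ug/mL in this assay, at which 2 of the 3 values shown sit.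

Compound 4 `COc1nc(-c2ccc(F)cc2)ccc1[C@@H](c1ccccc1)[C@@](O)(CCN(C)C)c1cccc2ccccc12` differs from compound 2 by fluoro in place of bromo on an aromatic carbon, a change that sits on the same 4-bromophenyl that enters in an at least 1.8-fold higher number from compound 1 to compound 2 (0.25 log units; that floor lies within the scatter). Within the data shown here, no measured step covers this halogen exchange, and the only step that exists has a floor within the scatter. Compound 4 is therefore expected to show an at least 1.1-fold lower number from compound 2 to compound 4 (0.04 log units; that floor lies within the scatter) in this assay, nothing beyond the scatter. The estimate for compound 4 in this assay is 45 ug/mL, ranging from 22 ug/mL to 90 ug/mL.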

Compound 4, half-maximal cytotoxic concentration: > 50 ug/mL
Compound 4: a limit, no number; the forecaster's own chance of this, stated with the estimate: 60%; middle value at least 1.1-fold (0.04 log units) away from the limit.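

Fluoro in place of bromo leaves compound 4 at a limit of this assay, as compound 2 was, so reaching that limit does not depend on the bromine alone. A second replacement of tert-butyl now points the same way, an at least 1.8-fold higher number from compound 1 to compound 4 (0.25 log units; that floor lies within the scatter), while the step between the two halogens cannot be read, since both ends of it are limits. The upper edge of the assay now holds most of the set: the limit of > 50 ug/mL in this assay, at which 3 of the 4 values shown sit.

From the compounds shown here alone, how far past that limit compound 2 and compound 4 lie stays unknown, so no order between the two halogens can be given. Also open, going by these compounds, is whether an amine or a carboxylic acid on the same aromatic carbon, para to a large group, would bring the number into the readable range.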